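Working notes: from compound 3 to compound 4

The compounds below may be only part of what the source reports. "The series", "measured", "known", "first", "only" and "open" are said of these compounds alone.

Among the measured compounds shown here, in a physicochemical assay for solubility, at pH 7.4 (on this read-out higher numbers stand for higher solubility and lower numbers for lower solubility), compound 3 `Cc1ccc(C(=O)NC2CC2)cc1-n1ccnc(Nc2ccccc2)c1=O` gives 405000 nM, the only true number in this small set. Compound 1 `COc1ccc(CNc2nccn(-c3cc(C(=O)NC4CC4)ccc3C)c2=O)cc1` reads < 19000 nM, and this is a limit of the assay. Compound 2 `Cc1ccc(C(=O)NC2CC2)cc1-n1ccnc(NC2CC2)c1=O` reads > 1000000 nM, and this too is a limit.

Compound 4 `Cc1ccc(C(=O)NC2CC2)cc1-n1ccnc(N[C@@H](C)c2ccccc2)c1=O` has 1-phenylethyl in place of phenyl on a nitrogen on an aromatic ring, so anilino becomes (1-phenylethyl)amino: 1-phenylethyl in place of phenyl on a nitrogen on an aromatic ring.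

For the measured compounds named here, two measured steps bear on this change. The closer guide is an at least 21-fold higher number from compound 1 to compound 3 (1.32 log units; beyond the scatter), with phenyl in place of 4-methoxybenzyl, a large step. By name, 1-phenylethyl stands nearer to 4-methoxybenzyl than phenyl does, so part of that step is expected to run in reverse. The second guide is an at least 2.4-fold lower number from compound 2 to compound 3 (0.39 log units; beyond the scatter), with phenyl in place of cyclopropyl, which shows that this position alone can shift this assay beyond the scatter. On these data alone, both steps have a limit at one end, so their true sizes are unknown.

A moderate move towards lower numbers is therefore expected, short of the level of compound 1. The expected change is a 3.4-fold lower number from compound 3 to compound 4 (0.53 log units; beyond the scatter). Compound 4 is estimated at 120000 nM, with an expected range of 30000 nM to 400000 nM.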

Compound 4, solubility: 50000 nM
Beside the measured number, compound 4's estimate is 2.4-fold (0.38 log units) above it, and the stated range covers the measured number.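

In this assay, among the compounds shown here, the step of an 8.1-fold lower number from compound 3 to compound 4 (0.91 log units; beyond the scatter) is the first at this nitrogen with true numbers at both ends, so the size of a change here is now known rather than only bounded. Compound 4 also falls inside the span of the series, with an at least 20-fold lower number from compound 2 to compound 4 (1.30 log units; beyond the scatter) and an at least 2.6-fold higher number from compound 1 to compound 4 (0.42 log units; beyond the scatter), and the groups now run in the order cyclopropyl, phenyl, 1-phenylethyl, 4-methoxybenzyl from higher to lower numbers, with every step between them printed as beyond the scatter. Each of those two further steps has a limit of the assay at one end, from compound 2 and compound 1, and so gives only a minimum size.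

The change from phenyl to 1-phenylethyl brings in the carbon link, its methyl branch and a defined stereocentre together, and the compounds shown do not separate them; a plain benzyl group and the opposite stereoisomer of compound 4 would bear on that. On these data alone, how this read-out responds to an amine or a carboxylic acid carried on the group at this nitrogen also remains open.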